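From Iodo to Methyl in a Small Series

A few compounds are considered here, and "the series" means these few. Any claim that something is new, unique, unknown or untested is made for them only; others in the source may bear on it.

In a functional assay on MOLT-4 cells (Homo sapiens) for antiproliferative activity, with a stated time of 48 h (on this read-out lower numbers stand for stronger inhibition and higher numbers for weaker inhibition), compound 1 `C=C(Br)C(=O)Nc1ccc(/C=C/C(=O)c2ccc(Cl)cc2)cc1` gives 810 nM, compound 2 `C=C(Br)C(=O)Nc1ccc(/C=C/C(=O)c2ccc(Cl)c(Cl)c2)cc1` gives 1800 nM and compound 3 `C=C(Br)C(=O)Nc1ccc(/C=C/C(=O)c2ccc(I)cc2)cc1` gives 2800 nM. Compound 3 sits at the upper end of these numbers: the data show a 1.6-fold higher number from compound 2 to compound 3 (0.19 log units; within the scatter), and also a 3.5-fold higher number from compound 1 to compound 3 (0.54 log units; beyond the scatter). Compound 4 `C=C(Br)C(=O)Nc1ccc(/C=C/C(=O)c2ccc(C)cc2)cc1` differs from compound 3 by methyl in place of iodo on an aromatic carbon, with methyl in place of iodo on an aromatic carbon, para to a large group. Within the data shown here, only one measured step changes this same spot: read in reverse, a 3.5-fold higher number from compound 1 to compound 3 (0.54 log units; beyond the scatter) shows that replacing the iodo of compound 3 can lower the number modestly. Among the measured compounds shown here, no methyl compound has been measured, so a small move to a lower number in this assay is expected, perhaps no larger than the scatter. The expected change is a 1.9-fold lower number from compound 3 to compound 4 (0.27 log units; within the scatter). Compound 4 is estimated at 1500 nM, with an expected range of 600 nM to 3500 nM.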

Compound 4, half-maximal inhibitory concentration: 1700 nM
Beside the measured number, compound 4's estimate is 1.1-fold (0.05 log units) below it; the measured number falls inside the stated range.
By their numbers in this assay, from the lowest: compound 1; then compounds 4, 2 and 3 (each within the scatter of the next).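

Among these compounds, compound 4 brings the first non-halogen group to this spot, and the change from iodo to methyl makes no clear difference: a 1.6-fold lower number from compound 3 to compound 4 (0.22 log units; within the scatter) lies within the scatter. The methyl compound also cannot be separated from the dichloro compound, with a 1.1-fold lower number from compound 2 to compound 4 (0.02 log units; within the scatter) again within the scatter. Chloro remains apart from methyl, as a 2.1-fold higher number from compound 1 to compound 4 (0.32 log units; beyond the scatter) lies beyond the scatter, so compound 1 keeps the lowest number of the four.

On these data alone, whether an amine or a carboxylic acid at this spot would match chloro or methyl stays open. No measurement shown offers a reason for chloro's separation from methyl.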